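A few compounds are considered here, and "the series" means these few. Any claim that something is new, unique, unknown or untested is made for them only; others in the source may bear on it.

In a functional assay on DU-145 cells (Homo sapiens) for cytotoxicity, read by MTT assay, with a stated time of 48 h (a higher number here means a weaker inhibitor, a lower number a stronger inhibitor), compound 1 `CCn1c(/C=C2/C(=O)Nc3ccc(F)cc32)nc2ccccc21` gives 40600 nM. Compound 2 `CC(C)n1c(/C=C2/C(=O)Nc3ccc(F)cc32)nc2ccccc21` gives 24500 nM, and the measured change, a 1.7-fold lower number from compound 1 to compound 2 (0.22 log units; within the scatter), leaves the two values within the usual scatter of each other. Compound 3 `Cn1c(/C=C2/C(=O)Nc3ccc([N+](=O)[O-])cc32)nc2ccccc21` gives > 50000 nM, which is a limit and not a number. That result marks (the limit of > 50000 nM in this assay, at which 1 of the 3 values shown sits). Compound 4 `CCn1c(/C=C2/C(=O)Nc3ccc(Br)cc32)nc2ccccc21` is still unmeasured. It keeps the core of compound 1 and has bromo in place of fluoro on an aromatic carbon. Among the compounds with values here, no measured step tests a change at this place. Within the data shown here, the nearest evidence is the single step at another site, a 1.7-fold lower number from compound 1 to compound 2 (0.22 log units; within the scatter), and it does not go beyond the scatter. On that limited basis, no step beyond the scatter is expected in this assay, and no direction can be firmly assigned. The expected change is a 1.2-fold lower number from compound 1 to compound 4 (0.09 log units; within the scatter). For compound 4 the estimated value is 33000 nM. The expected range for compound 4 runs from 14000 nM to 50000 nM.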

Compound 4, half-maximal inhibitory concentration: 45800 nM
The estimate for compound 4 lay 1.4-fold (0.14 log units) below the measured number, within the range that was stated.
By their numbers in this assay, from the lowest: compounds 2, 1 and 4 (each within the scatter of the next). At a limit, above all of these: compound 3.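

In this assay, bromo in place of fluoro on this aromatic carbon, meta to a fused ring and para to a fused ring, gives a 1.1-fold higher number from compound 1 to compound 4 (0.05 log units; within the scatter). This is the only single change shown at this position, and the assay does not separate fluoro from bromo here, so the position now has a direct test that the earlier compounds did not supply. Nothing measured here gives a cause for this result.

On these data alone, whether an amine or a methoxy group at this position would give a number outside the scatter of compound 1 remains open. Compound 3, which has nitro at this position, also differs from compound 1 in a second place. Compound 3 gives > 50000 nM, which is a limit and not a number.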